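Swapping the furan for a cyanophenyl in compound 3

The compounds below may be only part of what the source reports. "The series", "measured", "known", "first", "only" and "open" are said of these compounds alone.

The series shares one core and is tested in a functional assay on CHO-K1 cells for antagonist activity at adenosine receptor A1 (Homo sapiens), read by a beta-galactosidase reporter and cAMP accumulation, with stated times of 15 min and 6 h; a higher number here means a weaker inhibitor, a lower number a stronger inhibitor. Compound 1 `Cc1ccc(-c2nc(N)c3cc(Cc4ccccc4F)sc3n2)o1` reaches only the limit of this assay, giving < 16 nM. Compound 2 `Cc1ccc(-c2nc(N)c3cc(C(C)c4ccccc4)sc3n2)o1` gives 439 nM. Compound 3 `Nc1nc(-c2ccc(C3CC3)o2)nc2sc(Cc3ccccc3)cc12` gives 861 nM, the highest of the two numbers actually reported; its nearest neighbour is compound 2, whose number is within the scatter of it, so no order between the two can be claimed. Among the measured compounds shown here, the one step that can be sized, an at least 27-fold higher number from compound 1 to compound 2 (1.43 log units; beyond the scatter), touches the other side of the core and rests on a limit, (the limit of < 16 nM in this assay, at which 1 of the 3 values shown sits).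

Compound 4 `N#Cc1cccc(-c2nc(N)c3cc(Cc4ccccc4)sc3n2)c1` differs from compound 3 only at the far end of the molecule: 3-cyanophenyl in place of 5-cyclopropylfuran-2-yl on an aromatic carbon. For the measured compounds named here, no measured step in the set changes this position, so the step from compound 1 to compound 2 offers no direct guide. With nothing to point the other way, compound 4 is expected to stay close to compound 3, with a 1.4-fold higher number from compound 3 to compound 4 (0.14 log units; within the scatter) amounting to no change beyond the scatter. The estimate for compound 4 in this assay is therefore 1200 nM, with a range from 300 nM to 5000 nM.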

Compound 4, inhibition constant: 222 nM
For compound 4 the middle estimate is 5.4-fold (0.73 log units) above the measured one; measured number below the stated range.
By their numbers in this assay, from the lowest: compounds 4, 2 and 3 (each within the scatter of the next, the first and the last beyond it). At a limit, below all of these: compound 1.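

In this assay, this position, on an aromatic carbon between two ring nitrogen atoms, proves sensitive to the group it carries: with 3-cyanophenyl in place of 5-cyclopropylfuran-2-yl there is a 3.9-fold lower number from compound 3 to compound 4 (0.59 log units; beyond the scatter). Among the compounds shown here, this is the first step in the set to read this position, and it shows that the exchange matters even though both groups hold 8 heavy atoms and 1 hydrogen-bond acceptor and neither has a net charge, so these counts do not separate them. Nothing in the data shown accounts for the size of this step.

Going by these compounds, with only these two groups at this position, it remains open whether the nitrile matters or the six-membered aromatic ring alone, and how a phenyl carrying no substituent, or one with an amine or a carboxylic acid in place of the nitrile, would read in this assay. On these data alone, it is also open whether the step would hold if the benzyl group shared by compound 3 and compound 4 gave way to 2-fluorobenzyl or 1-phenylethyl.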